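Varying the aryl on the sulfonyl sulfur

This account rests on a few compounds, and the source may have more. Where it says the series, first, only, none or still open, it means among the compounds named here.

Three compounds of the series carry a number in an assay on isolated protein for displacement of a labelled ligand from metabotropic glutamate receptor 5 (Homo sapiens), with a stated time of 60 min, tested at 1 uM; a lower number here means less inhibition, a higher number more inhibition at the concentration tested (going by the name of the read-out). Compound 1 `Cc1cc(C)cc(S(=O)(=O)c2cnc3ccc(C)cc3c2N2CCC(C)CC2)c1` gives 80%. Compound 2 `COc1ccc2ncc(S(=O)(=O)c3ccc(OC)c(Cl)c3)c(N3CCC(C)CC3)c2c1` gives 21%, and compound 3 `COc1ccc2ncc(S(=O)(=O)c3ccc(C)c(F)c3)c(N3CCC(C)CC3)c2c1` gives 73%. Among the compounds with values here, compound 3 thus stands second of the three: its number lies within the scatter of compound 1 and well beyond that of compound 2, the step of a number 52 percentage points higher from compound 2 to compound 3 (beyond the scatter) being the only single-place change measured so far.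

Compound 4 `COc1ccc2ncc(S(=O)(=O)c3cc(C)cc(C)c3)c(N3CCC(C)CC3)c2c1` is not yet measured. It differs from compound 3 by 3,5-dimethylphenyl in place of 3-fluoro-4-methylphenyl on a sulfonyl sulfur. Within the data shown here, no measured step covers this exact exchange. Among the measured compounds shown here, the one measured step, a number 52 percentage points higher from compound 2 to compound 3 (beyond the scatter), concerns a different pair of aryl groups on the same sulfur and shows that this position can move the number widely. Compound 4 carries the same 3,5-dimethylphenyl on the sulfonyl sulfur as compound 1, with a core that differs from that of compound 1 in one group; compound 1 gives 80%, within the scatter of compound 3. The step of a number 5 percentage points higher from compound 3 to compound 4 (within the scatter) is therefore expected to stay within the scatter. For compound 4 the estimate in this assay is 78%, ranging 62% to 92%.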

Compound 4, a percentage reported as inhibition, at one concentration (the size of the read-out at that concentration, not a potency): 79%
Beside the measured number, compound 4's estimate is 1 percentage points below it; low and high end bracket the measured number.
By their numbers in this assay, from the lowest: compound 2; then compounds 3, 4 and 1 (each within the scatter of the next).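

In this assay the exchange on the sulfonyl sulfur gives a number 6 percentage points higher from compound 3 to compound 4 (within the scatter) so 3,5-dimethylphenyl and 3-fluoro-4-methylphenyl cannot be told apart at this position. 3-Chloro-4-methoxyphenyl now stands apart from two other aryl groups, with a number 58 percentage points higher from compound 2 to compound 4 (beyond the scatter) as the second large step at this sulfur. Methoxy in place of methyl on an aromatic carbon, the first measured change away from the sulfonyl aryl, gives a number 1 percentage points lower from compound 1 to compound 4 (within the scatter) and so makes no measurable difference with 3,5-dimethylphenyl on the sulfur. Nothing available explains why the aryl exchanges differ so widely.

The compounds shown do not separate the contribution of the chlorine from that of the methoxy in 3-chloro-4-methoxyphenyl. On these data alone, how an aryl group carrying an amine, a carboxylic acid or a nitrile would behave on the sulfonyl sulfur also remains open.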